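Benzylamine variation in a bis(trifluoromethyl)sulfonamide series

The source may report more compounds than this note shows. Statements on the series, on what has been measured and on what is new or still open speak of the compounds shown alone.

Measured compounds:
compound 1, `O=S(=O)(NCCCNCc1cccc2ccccc12)c1cc(C(F)(F)F)cc(C(F)(F)F)c1`, 3100 nM
compound 2, `COc1ccc(CNCCCNS(=O)(=O)c2cc(C(F)(F)F)cc(C(F)(F)F)c2)cc1OC`, 3800 nM
compound 3, `COc1ccccc1CNCCCNS(=O)(=O)c1cc(C(F)(F)F)cc(C(F)(F)F)c1`, 1500 nM

These three share one core and differ only in the aryl group on a saturated chain carbon bound to an amine nitrogen. In a functional assay on A2780 cells (Homo sapiens) for inhibition, read by MTT assay, with a stated time of 72 h (on this read-out lower numbers stand for stronger inhibition of growth and higher numbers for weaker inhibition of growth), compound 3 gives the lowest number of the three; the two steps that lead to it are a 2.1-fold lower number from compound 1 to compound 3 (0.32 log units; beyond the scatter) and a 2.5-fold lower number from compound 2 to compound 3 (0.40 log units; beyond the scatter), both modest but beyond the scatter, whereas compound 1 and compound 2 lie within the scatter of each other, a 1.2-fold higher number from compound 1 to compound 2 (0.09 log units; within the scatter).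

Compound 4 is `O=S(=O)(NCCCNCc1ccc(Br)cc1)c1cc(C(F)(F)F)cc(C(F)(F)F)c1`. Its change from compound 3 is 4-bromophenyl in place of 2-methoxyphenyl on a saturated chain carbon bound to an amine nitrogen. For the measured compounds named here, no measured step puts a bromine on the ring, so only the general spread among compound 1, compound 2 and compound 3 bears on it: every aryl replacement so far moved the number by a modest amount at most. A similarly sized, probably weakening step is therefore expected, a 1.9-fold higher number from compound 3 to compound 4 (0.27 log units; within the scatter). For compound 4 the estimate in this assay is 2800 nM, with a range from 1200 nM to 6500 nM.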

Compound 4, concentration for 50% growth inhibition: 2600 nM
For compound 4 the middle estimate is 1.1-fold (0.03 log units) above the measured one; the range from low to high includes it.
By their numbers in this assay, from the lowest: compounds 3, 4, 1 and 2 (each within the scatter of the next, the first and the last beyond it).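

In this assay the 4-bromophenyl group, with no hydrogen-bond acceptor where 2-methoxyphenyl has one, gives a 1.7-fold higher number from compound 3 to compound 4 (0.24 log units; within the scatter) and so introduces a bromine without a step beyond the scatter. Compound 4 also shows a 1.5-fold lower number from compound 2 to compound 4 (0.16 log units; within the scatter) and a 1.2-fold lower number from compound 1 to compound 4 (0.08 log units; within the scatter) and therefore lies within the scatter of all three earlier compounds, which blurs the separation of compound 3 from compound 1 and compound 2 seen before. Nothing measured here explains these numbers.

Because 2-methoxyphenyl and 4-bromophenyl differ in both the substituent and its place on the ring, the compounds shown cannot separate those two changes. From the compounds shown here alone, it remains open how a 2-bromophenyl, a 4-methoxyphenyl or an unsubstituted phenyl would read at this position.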